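Hydroxy on the chain carbon: compound 3 to compound 4

A few compounds are considered here, and "the series" means these few. Any claim that something is new, unique, unknown or untested is made for them only; others in the source may bear on it.

Of the compounds shown here, three of the shared core have been measured in a functional assay on DU-145 cells (Homo sapiens) for cytotoxicity, read by MTT assay, with a stated time of 24 h; on this read-out higher numbers stand for weaker inhibition and lower numbers for stronger inhibition. Compound 1 `C=C1C(=O)[C@H]2C[C@]1(O)CC1=C2[C@]2(C)CCC[C@](C)(CO)[C@H]2CC1` carries a methylene on the ring ketone, and in this assay compound 1 gives 9400 nM. Compound 2 `C[C@@H]1C(=O)[C@H]2C[C@]1(O)CC1=C2[C@]2(C)CCC[C@](C)(CO)[C@H]2CC1` has a methyl in its place. In this assay compound 2 gives only a limit, > 50000 nM. Compound 3 `C[C@@H]1C(=O)[C@H]2C[C@]1(O)CC1=C2[C@]2(C)CCCC(C)(C)[C@H]2CC1` drops the hydroxy of compound 2 on the saturated chain carbon. In this assay compound 3 likewise gives only a limit, > 50000 nM. The step that the two limits leave unreadable from compound 2 to compound 3 is therefore not readable, because of the limit of > 50000 nM in this assay, at which 2 of the 3 values shown sit.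

Compound 4 `C[C@@H]1C(=O)[C@H]2C[C@]1(O)CC1=C2[C@]2(C)CCC[C@@](C)(CO)[C@H]2CC1` restores a hydroxy at the other configuration of the same center: hydroxy in place of hydrogen on a saturated chain carbon bound to a saturated ring carbon. Among the compounds with values here, the only measured step that bears on it, the step from compound 2 to compound 3, sits between two limits and gives no size. Compound 2 and compound 3 both lie at the limit, so compound 4 is expected to remain there as well, and the step that the limit leaves unreadable from compound 3 to compound 4 is estimated as no change beyond the scatter. Compound 4 is expected to give 70000 nM in this assay, within 20000 nM to 250000 nM.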

Compound 4, half-maximal inhibitory concentration: > 50000 nM
Compound 4 gave a limit, no number (the forecaster's own chance of this, stated with the estimate: 75%); the middle value lies beyond the limit too.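

Compound 4, like compound 2 and compound 3, gives only a limit, so no step among these three compounds can be read: the limit of > 50000 nM in this assay, at which 3 of the 4 values shown sit. On these data alone, whether the hydroxy on the saturated chain carbon, or its configuration, affects cytotoxicity in this methyl series remains open.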